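The compounds below may be only part of what the source reports. "The series", "measured", "known", "first", "only" and "open" are said of these compounds alone.

Measured in a functional assay on A549 cells (Homo sapiens) for inhibition, read by sulforhodamine B assay, with a stated time of 72 h; a lower number here means a stronger inhibitor of growth, a higher number a weaker inhibitor of growth:
Compound 1 `O=C(CCc1ccncc1-c1ccc2ccccc2c1)N1CCOCC1`: > 10000 nM (a limit)
Compound 2 `CNC(=O)CCc1ccncc1-c1ccc2ccccc2c1`: 10400 nM

Among the compounds with values here, compound 2, at 10400 nM, carries the only actual number in this assay. The result for compound 1 is only a limit: the limit of > 10000 nM in this assay, at which 1 of the 2 values shown sits.

Compound 3 `O=C(/C=C/c1ccncc1-c1ccc2ccccc2c1)NC1CC1` differs from compound 2 in one place: 2-(cyclopropylcarbamoyl)ethenyl in place of 2-(methylcarbamoyl)ethyl on an aromatic carbon. In words, 2-(cyclopropylcarbamoyl)ethenyl stands in place of 2-(methylcarbamoyl)ethyl on an aromatic carbon.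

Within the data shown here, the one measured step, a step that the limit leaves unreadable from compound 1 to compound 2, has no readable size and concerns only the group on the carbonyl carbon, so it gives no size to carry over. No step beyond the usual scatter is therefore expected in this assay, and no direction can be favoured. The expected change is a 1.2-fold lower number from compound 2 to compound 3 (0.06 log units; within the scatter). For compound 3 the estimated value is 9000 nM, with an expected range of 3000 nM to 20000 nM.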

Compound 3, concentration for 50% growth inhibition: 5840 nM
Compound 3: middle estimate off by 1.5-fold (0.19 log units), on the high side; the range from low to high includes it.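

In this assay, the change at this position, on an aromatic carbon opposite the ring nitrogen, gives a 1.8-fold lower number from compound 2 to compound 3 (0.25 log units; within the scatter), so 2-(cyclopropylcarbamoyl)ethenyl and 2-(methylcarbamoyl)ethyl cannot be told apart here. Within the data shown here, this is the first readable step, since the earlier step on the carbonyl carbon cannot be read, and it shows that this larger chain with its added double bond and three-membered ring is accepted at this position without a change beyond the scatter. Nothing shown gives a cause for this result.

Going by these compounds, the ethenyl link and the cyclopropyl group enter together, so their separate contributions remain open. Also open, on these data alone, is whether a carboxylic acid or an amine at the end of the chain, or a longer chain, would move the number in this assay beyond the scatter.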